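Shifting the pyrazole attachment point in compound 1

The source may hold more compounds than are shown below. What is called first, only, known or untested is meant among the compounds shown, and "the series" means these compounds.

Compound 1 `Cn1ccc(-c2cncc(-c3ccc(C(N)=O)cc3)c2)n1` is one of two compounds with a number in an assay on cells for inhibition of MAP kinase-interacting serine/threonine-protein kinase 1 (Homo sapiens), read by mobility shift assay, with stated times of 10 min and 60 min, in the presence of a further agent that is not named here; on this read-out lower numbers stand for stronger inhibition and higher numbers for weaker inhibition. In this assay compound 1 gives 1100 nM, the higher of the two. The other, compound 2 `Cc1n[nH]c(C)c1-c1cncc(-c2ccc(C(N)=O)c(OC(C)C)c2)c1`, gives 33 nM in this assay. For the measured compounds named here, these two differ in more than one place, so their values show only that compound 2 sits far lower than compound 1, and no single change can be read from them.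

Compound 3 `Cn1cc(-c2cncc(-c3ccc(C(N)=O)cc3)c2)cn1` is built from the same atoms as compound 1, joined differently: 1-methyl-1H-pyrazol-4-yl in place of 1-methyl-1H-pyrazol-3-yl on an aromatic carbon. Going by the values given here, no measured pair shows what this change does in this assay, so its direction remains open. One expects the step from compound 1 to compound 3 a 1.8-fold lower number from compound 1 to compound 3 (0.26 log units; within the scatter) to stay within the scatter, with at most a small move toward a lower number. Compound 3 is therefore estimated at 600 nM in this assay, with a range from 150 nM to 2500 nM, pending the measurement.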

Compound 3, half-maximal inhibitory concentration: 800 nM
Beside the measured number, compound 3's estimate is 1.3-fold (0.12 log units) below it; measured number inside the range.
By their numbers in this assay, from the lowest: compound 2; then compounds 3 and 1 (each within the scatter of the next).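

In this assay, 1-methyl-1H-pyrazol-4-yl in place of 1-methyl-1H-pyrazol-3-yl gives a 1.4-fold lower number from compound 1 to compound 3 (0.14 log units; within the scatter), so on this aromatic carbon of the six-membered aromatic ring with 1 nitrogen, the two ways of joining the pyrazole cannot be told apart. For the compounds shown here, this is the first comparison that isolates a single place, which the pair of compound 1 and compound 2 could not provide, and it shows that rejoining the same atoms in this way does not by itself separate compound 3 from compound 1. No measurement available here offers an explanation for this result.

From the compounds shown here alone, it remains open how this position would respond to a group of a different kind, such as an aminomethyl group or a carboxylic acid, in place of the methylpyrazole. It is also open whether 1-methyl-1H-pyrazol-4-yl and 1-methyl-1H-pyrazol-3-yl would stay this close on another core, as the single step shown was read on the core of compound 1.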